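The source may hold more compounds than are shown below. What is called first, only, known or untested is meant among the compounds shown, and "the series" means these compounds.

Compound 1 `COc1ccc(C(=O)/C=C/c2ccccc2)cc1[N+](=O)[O-]` was examined in a functional assay on B16 cells (Mus musculus) for cytotoxicity, read by MTT assay, with a stated time of 3 days; on this read-out higher numbers stand for weaker inhibition and lower numbers for stronger inhibition. In this assay compound 1 gives > 100000 nM, which is a limit of the assay and not a number. Compound 2 `COc1ccc(/C=C/C(=O)c2ccc(OC)c([N+](=O)[O-])c2)cc1` carries a methoxy in place of a hydrogen on an aromatic carbon. In this assay compound 2 gives > 100000 nM, again a limit rather than a measured number. Between the two the data show a step that the two limits leave unreadable from compound 1 to compound 2. Both values sit at the limit of > 100000 nM in this assay, at which 2 of the 2 values shown sit, so no comparison available here yields a readable size. Compound 3 `COc1cccc(/C=C/C(=O)c2ccc(OC)c([N+](=O)[O-])c2)c1` differs from compound 1 by methoxy in place of hydrogen on an aromatic carbon. Among the compounds with values here, the only change of the same kind that was measured, the methoxy added on an aromatic carbon between compound 1 and compound 2, remained unreadable, so there is no measured ground for a step beyond the scatter in either direction. Compound 3 is expected to stay at the limit as well, and the estimated step that the limit leaves unreadable from compound 1 to compound 3 is accordingly close to none. The estimate for compound 3 is 150000 nM, with a range from 50000 nM to 500000 nM.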

Compound 3, half-maximal inhibitory concentration: > 100000 nM
Compound 3: no number, only a limit; the forecaster's own chance of this, stated with the estimate: 80%; the middle value is on the limit's open side.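

Within the data shown here, compound 3, like compound 1, gives only a limit of the assay and not a number, so no step between them can be read: the limit of > 100000 nM in this assay, at which 3 of the 3 values shown sit. The compounds shown leave open how strongly any of the three inhibits in this assay and whether adding a methoxy makes any difference there.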